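The source may hold more compounds than are shown below. What is called first, only, known or untested is meant among the compounds shown, and "the series" means these compounds.

Measured in an ADME assay on Vero cells (Chlorocebus sabaeus) for cytotoxicity, read by MTT assay, with a stated time of 72 h; on this read-out lower numbers stand for higher toxicity in this test and higher numbers for lower toxicity in this test:
- compound 1 `CO/N=C1\C(=O)N(CN2CCN(c3c(F)cc4c(=O)c(C(=O)O)cn(C5CC5)c4c3OC)CC2)c2ccc(F)cc21`: 46800 nM
- compound 2 `CCO/N=C1\C(=O)N(CN2CCN(c3c(F)cc4c(=O)c(C(=O)O)cn(C5CC5)c4c3OC)CC2)c2ccccc21`: 91500 nM

On these numbers, compound 2 stands level with compound 1, as their two values lie within the usual scatter of each other. Compound 3 `CCO/N=C1\C(=O)N(CN2CCN(c3c(F)cc4c(=O)c(C(=O)O)cn(C5CC5)c4c3OC)CC2)c2ccc(F)cc21` is compound 2 with fluoro in place of hydrogen on an aromatic carbon. The two measured compounds differ in more than one place, so the data show no direct measure of this change. No step beyond the scatter is expected in this assay, an expectation that rests on compound 2 at 91500 nM and compound 1 at 46800 nM lying within the scatter of each other. The estimate amounts to a 1.4-fold lower number from compound 2 to compound 3 (0.15 log units; within the scatter), which is expected to stay within the scatter. For compound 3 the estimated half-maximal cytotoxic concentration is 65000 nM, with an expected range of 30000 nM to 130000 nM.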

Compound 3, half-maximal cytotoxic concentration: 85800 nM
Estimate against measurement, compound 3: 1.3-fold (0.12 log units) below; low and high end bracket the measured number.
By their numbers in this assay, from the lowest: compounds 1, 3 and 2 (each within the scatter of the next).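

In this assay, fluoro in place of hydrogen on this aromatic carbon now has a direct reading (a 1.1-fold lower number from compound 2 to compound 3 (0.03 log units; within the scatter)), which compound 1 and compound 2 could not give, as they differ in more than one place. Compound 3 also gives a direct reading for methyl in place of hydrogen on a saturated chain carbon bound to an oxygen on an unsaturated carbon (a 1.8-fold higher number from compound 1 to compound 3 (0.26 log units; within the scatter)), so each single change, taken alone, stays within the scatter in these compounds. Nothing at hand speaks to the reason for this result.

From the compounds shown here alone, it remains open whether chloro or an amine on the same aromatic carbon would also stay within the scatter. The same question stands for a chain longer than ethyl on that oxygen.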